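The source may report more compounds than this note shows. Statements on the series, on what has been measured and on what is new or still open speak of the compounds shown alone.

Measured so far:
compound 1 `COc1ccc(C2CC(c3ccccc3)=NN2C2=NC(=O)/C(=C3\C(=O)Nc4ccc(Br)cc43)S2)cc1` — 550 nM
compound 2 `COc1ccc(C2=NN(C3=NC(=O)/C(=C4\C(=O)Nc5ccc(Br)cc54)S3)C(c3ccc(OC)cc3)C2)cc1` — 410 nM

In a functional assay on cells (Melanoma cell, Homo sapiens) for cytotoxicity, read by sulforhodamine B assay, with a stated time of 48 h (a higher number here means a weaker inhibitor of growth, a lower number a stronger inhibitor of growth), compound 1 gives 550 nM, and compound 2 gives 410 nM; the step of a 1.3-fold lower number from compound 1 to compound 2 (0.13 log units; within the scatter) leaves the two numbers within the scatter of each other. Compound 3 `CN(C)c1ccc(C2CC(c3ccccc3)=NN2C2=NC(=O)/C(=C3\C(=O)Nc4ccc(Br)cc43)S2)cc1` differs from compound 1 by dimethylamino in place of methoxy on an aromatic carbon. Among the compounds with values here, no measured step exchanges a methoxy for another group; the only step at hand, a 1.3-fold lower number from compound 1 to compound 2 (0.13 log units; within the scatter), bears on the same aromatic position but only indirectly. No movement beyond the scatter is therefore expected, with the step estimated as a 1.1-fold lower number from compound 1 to compound 3 (0.04 log units; within the scatter). Compound 3 is estimated at 500 nM, within 250 nM to 1100 nM.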

Compound 3, concentration for total growth inhibition: 460 nM
For compound 3 the middle estimate is 1.1-fold (0.04 log units) above the measured one; measured number inside the range.
By their numbers in this assay, from the lowest: compounds 2, 3 and 1 (each within the scatter of the next).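

In this assay, the exchange of 4-methoxyphenyl for 4-(dimethylamino)phenyl gives a 1.2-fold lower number from compound 1 to compound 3 (0.08 log units; within the scatter). Within the data shown here, this is the first change at this aromatic carbon itself, as the earlier step placed methoxy on a different one, and here too the numbers stay within the scatter. Nothing available explains this tolerance.
Still open, as far as these compounds go, is whether a carboxylic acid or a longer alkoxy chain at this place would move the number beyond the scatter. Also open, from the compounds shown here alone, is whether dimethylamino behaves alike on the core of compound 2.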